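Estimating a Dimethoxyphenyl Variant of Compound 1

The source may hold more compounds than are shown below. What is called first, only, known or untested is meant among the compounds shown, and "the series" means these compounds.

Measured compounds:
compound 1 `OC[C@H]1O[C@@H](n2cnc3c(NCc4ccccc4F)ncnc32)[C@H](O)[C@@H]1O`, 4600 nM
compound 2 `COc1cccc(CNc2ncnc3c2ncn3[C@@H]2O[C@H](CO)[C@@H](O)[C@H]2O)c1`, 7600 nM

Of the compounds shown here, two have been measured in a functional assay on CCRF-CEM cells (Homo sapiens) for antiproliferative activity, with a stated time of 72 h; a higher number here means a weaker inhibitor, a lower number a stronger inhibitor. Compound 1 holds the lowest of the two numbers, and its nearest neighbour is compound 2, whose value lies within the scatter of it. Going by the values given here, the one step between them, a 1.7-fold higher number from compound 1 to compound 2 (0.22 log units; within the scatter), replaces the 2-fluorophenyl group with a 3-methoxyphenyl group on a saturated chain carbon bound to a nitrogen on an aromatic ring, and that step does not rise beyond the scatter.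

The unmeasured compound 3 `COc1cc(CNc2ncnc3c2ncn3[C@@H]2O[C@H](CO)[C@@H](O)[C@H]2O)cc(OC)c1` differs from compound 1 as follows: 3,5-dimethoxyphenyl in place of 2-fluorophenyl on a saturated chain carbon bound to a nitrogen on an aromatic ring. This is the same kind of change at the same place as that from compound 1 to compound 2, only with a second methoxy group added, so the step from compound 1 to compound 2 is the only one that bears on it. Since that step stayed within the scatter, the account expects at most a small shift in this assay for compound 3, if any, in the direction of a somewhat higher number. The estimated step is a 1.5-fold higher number from compound 1 to compound 3 (0.18 log units; within the scatter). Compound 3 is thus expected to give 7000 nM, with a range from 2500 nM to 20000 nM.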

Compound 3, half-maximal inhibitory concentration: > 166000 nM
Compound 3: no number, only a limit (the forecaster's own chance of this, stated with the estimate: 10%); at least 23-fold (1.37 log units) between middle value and limit.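

Compound 3 gives no number in this assay, only a limit of the assay: the limit of > 166000 nM in this assay, at which 1 of the 3 values shown sits.

At this place, on a saturated chain carbon bound to a nitrogen on an aromatic ring, the change to 3,5-dimethoxyphenyl in place of 2-fluorophenyl gives an at least 36-fold higher number from compound 1 to compound 3 (1.55 log units; beyond the scatter), so the position does not accept every substituted phenyl group alike, which the step within the scatter to the 3-methoxyphenyl group of compound 2 could not show. Going by these compounds alone, the more telling comparison is the single change of methoxy in place of hydrogen on an aromatic carbon, an at least 21-fold higher number from compound 2 to compound 3 (1.33 log units; beyond the scatter), which ties the large loss to the second methoxy group rather than to the removal of the 2-fluorophenyl group or to the first methoxy group.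

The compounds shown leave open whether it is this particular second methoxy group that matters or any further group on that ring, such as a methyl, a chlorine or an amine. They also leave open whether a longer chain between the nitrogen and the 3,5-dimethoxyphenyl group would give a number in this assay again.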